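Working notes on cytotoxicity in a sulfonamide series

A few compounds are considered here, and "the series" means these few. Any claim that something is new, unique, unknown or untested is made for them only; others in the source may bear on it.

Measured so far:
compound 1, `Cc1ccc(S(=O)(=O)Nc2ccc3oc(-c4ccccc4)nc3c2)cc1`, gives 75000 nM in an ADME assay on HEK293 cells (Homo sapiens) for cytotoxicity, read by resazurin assay, with a stated time of 48 h; a higher number here means that more compound is tolerated, a lower number that less compound is tolerated.
compound 2, `O=S(=O)(Nc1ccc(-c2nc3ccccc3o2)cc1)c1ccc(F)cc1`, gives > 100000 nM in this assay, which is a limit of the assay and not a number.
compound 3, `Cc1ccccc1S(=O)(=O)Nc1ccc(-c2nc3ccccc3o2)cc1`, gives > 100000 nM in this assay, again a limit of the assay and not a number.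

Compound 1 stands as the only number shown; the other two values sit at the limit of > 100000 nM in this assay, at which 2 of the 3 values shown sit. Among the compounds with values here, the one measured step that exchanges the group on the sulfonyl sulfur, a step that the two limits leave unreadable from compound 2 to compound 3, is left unreadable by the two limits, so it gives no size to lean on.

Compound 4, `CS(=O)(=O)Nc1ccc2oc(-c3ccccc3)nc2c1`, differs from compound 1 as follows: methyl in place of 4-methylphenyl on a sulfonyl sulfur. Within the data shown here, no measured step replaces an aromatic group on the sulfonyl sulfur with a methyl, so nothing measured bears directly on this change. With no readable step to suggest a shift in either direction, the expected step from compound 1, a 1.1-fold higher number from compound 1 to compound 4 (0.03 log units; within the scatter), is none beyond the scatter. Compound 4 is therefore expected to give about 80000 nM in this assay, within the range 35000 nM to 180000 nM.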

Compound 4, half-maximal cytotoxic concentration: > 100000 nM
Compound 4: only a limit was reported; the forecaster's own chance of this, stated with the estimate: 45%; at least 1.2-fold (0.09 log units) between middle value and limit.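

Methyl in place of 4-methylphenyl on a sulfonyl sulfur gives the first readable step at this position, an at least 1.3-fold higher number from compound 1 to compound 4 (0.12 log units; that floor lies within the scatter) and so shows that the aromatic ring can leave without the number falling, though no firm rise is shown. Compound 4 gives > 100000 nM in this assay which is a limit of the assay and not a number. Compound 1 therefore remains the only number in the set, with the other compounds at the limit: the limit of > 100000 nM in this assay, at which 3 of the 4 values shown sit.

Going by these compounds, how far compound 4 lies past its limit stays open, so the true size of this step is unknown. Also open, on these data alone, is whether an amine, a carboxylic acid or a longer chain on the sulfonyl sulfur would bring the number down to a readable value.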